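This account rests on a few compounds, and the source may have more. Where it says the series, first, only, none or still open, it means among the compounds named here.

Measured compounds in a functional assay on cells (Mus musculus) for cytotoxicity, read by MTT assay, with a stated time of 24 h, tested at 10 uM; on this read-out lower numbers stand for a weaker effect and higher numbers for a stronger effect at the one concentration tested:
compound 1 `COc1cc(/C=N/NC(=O)c2ccncc2)cc(OC)c1O`: 65%
compound 2 `COc1cc(/C=N/NC(=O)OCc2ccccc2)cc(OC)c1O`: 69%
compound 3 `COc1cc(/C=N/NC(=O)OCc2ccccc2)cc(OC)c1OC`: 4%

Compound 2 gives the highest number of the three in this assay, though compound 1 sits within the scatter of it (a number 4 percentage points higher from compound 1 to compound 2 (within the scatter)), while compound 3 lies far lower (a number 65 percentage points lower from compound 2 to compound 3 (beyond the scatter)). Compound 4 `COc1cc(/C=N/NC(=O)OCc2ccccc2)cc(O)c1O` is derived from compound 2 by hydrogen in place of methyl on an oxygen on an aromatic ring. Among the measured compounds shown here, the step that bears on it is the one from compound 2 to compound 3, where methyl in place of hydrogen on an oxygen on an aromatic ring gave a large drop; compound 4 runs the opposite way, methoxy to hydroxy, on the same core. A step beyond the scatter downward is therefore not expected; the number for compound 4 is estimated at 72%, a step of a number 3 percentage points higher from compound 2 to compound 4 (within the scatter). The expected range for compound 4 runs from 55% to 90%.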

Compound 4, a percentage reported as activity, at one concentration (the size of the read-out at that concentration, not a potency): 57%
Beside the measured number, compound 4's estimate is 15 percentage points above it; the measured number falls inside the stated range.
By their numbers in this assay, from the lowest: compound 3; then compounds 4, 1 and 2 (each within the scatter of the next, the first and the last beyond it).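

In this assay, methoxy to hydroxy gives a number 12 percentage points lower from compound 2 to compound 4 (beyond the scatter), so a second free hydroxy on the ring does not raise the number and the read-out stays far from the collapse seen on methylating the free hydroxy, a number 65 percentage points lower from compound 2 to compound 3 (beyond the scatter). Changes on the ring oxygens therefore differ in size: the methyl-for-hydrogen step is large, while this hydrogen-for-methyl step is modest. No measurement shown gives a reason for either step.

Open, on these data alone, is what an amine or an ethoxy group would give at this oxygen. Also open, as far as these compounds go, is whether a carboxylic acid there would keep the number near that of compound 4.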